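A Fluorine Added to a Weak Sphingomyelinase Inhibitor

A few compounds are considered here, and "the series" means these few. Any claim that something is new, unique, unknown or untested is made for them only; others in the source may bear on it.

Compound 1 `O=C(NO)c1cccc(OCc2ccc(-c3noc(-c4cccc(F)c4)n3)cc2)c1`: > 100000 nM.
Compound 2 `COc1ccc(C(=O)NO)cc1OCc1ccc(-c2noc(-c3ccccc3)n2)cc1`: 15900 nM.
Compound 3 `COc1ccc(C(=O)NO)cc1OCc1noc(-c2ccccc2)n1`: 36500 nM.

All three were tested in an assay on isolated protein for inhibition of sphingomyelin phosphodiesterase (Homo sapiens), read by fluorescence, with a stated time of 30 min; a higher number here means a weaker inhibitor, a lower number a stronger inhibitor. The value of compound 1 is a limit of this assay, not a number (the limit of > 100000 nM in this assay, at which 1 of the 3 values shown sits). Of the two numbers shown, compound 3 has the higher one; compound 2 sits lower, and that gap is beyond the usual scatter. Compound 4 `COc1ccc(C(=O)NO)cc1OCc1noc(-c2ccccc2F)n1` is compound 3 with one change, (fluoro in place of hydrogen on an aromatic carbon). Within the data shown here, no measured pair shows this change, so the step of a 1.1-fold lower number from compound 3 to compound 4 (0.06 log units; within the scatter) is expected to be small, in no clear direction and likely within the scatter. Compound 4 is therefore estimated at 32000 nM, with a range from 10000 nM to 100000 nM.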

Compound 4, half-maximal inhibitory concentration: 21600 nM
Beside the measured number, compound 4's estimate is 1.5-fold (0.17 log units) above it; the range from low to high includes it.
By their numbers in this assay, from the lowest: compounds 2, 4 and 3 (each within the scatter of the next, the first and the last beyond it). At a limit, above all of these: compound 1.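

Replacing phenyl with 2-fluorophenyl, ortho to a large group, is now tested directly, and in this assay it gives a 1.7-fold lower number from compound 3 to compound 4 (0.23 log units; within the scatter). In this one pair, fluoro at this position neither clearly helps nor clearly harms. No measurement shown explains this step. On these data alone, whether another group here, such as chloro, methoxy or an amine, would move the number beyond the scatter stays open. So does the outcome of placing fluoro on other carbons of this ring, or of making the same change in compound 2.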